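This account rests on a few compounds, and the source may have more. Where it says the series, first, only, none or still open, it means among the compounds named here.

Within the data shown here, compound 2 `O=C(NC[C@@H](O)[C@H](O)[C@@H]1O[C@@](OCc2cccc(F)c2F)(C(=O)O)C[C@H](O)[C@H]1NS(=O)(=O)c1ccccc1[N+](=O)[O-])c1ccc(Cl)cc1` is one of two compounds measured in an in vitro assay on cells for binding affinity to myelin-associated glycoprotein (Mus musculus), read by surface plasmon resonance (on this read-out lower numbers stand for tighter binding and higher numbers for weaker binding), where compound 2 gives 1400 nM. Among the measured compounds shown here, the only other measured compound, compound 1 `CC(=O)N[C@H]1[C@H]([C@@H](O)[C@H](O)CNC(=O)c2ccc(Cl)cc2)O[C@@](OCc2cccc(F)c2F)(C(=O)O)C[C@@H]1O`, gives 2400 nM in this assay; the step of a 1.7-fold lower number from compound 1 to compound 2 (0.23 log units; within the scatter) shows the two lie within the scatter of each other. Compound 3 `O=C(CC1CCC1)N[C@H]1[C@H]([C@@H](O)[C@H](O)CNC(=O)c2ccc(Cl)cc2)O[C@@](OCc2cccc(F)c2F)(C(=O)O)C[C@@H]1O` differs from compound 2 by (cyclobutylmethyl)carbonyl in place of (2-nitrophenyl)sulfonyl on an amine nitrogen. For the measured compounds named here, the one measured step, which swapped an acetyl for the same sulfonyl group, was within the scatter, so the return to an acyl amide in compound 3 is expected to bring a step of a 1.4-fold higher number from compound 2 to compound 3 (0.13 log units; within the scatter) that does not exceed the scatter. Compound 3 is therefore estimated at 1900 nM, within a range of 700 nM to 5000 nM.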

Compound 3, dissociation constant: 5800 nM
The estimate for compound 3 lay 3.1-fold (0.48 log units) below the measured number, and the stated range ends below it.
By their numbers in this assay, from the lowest: compounds 2 and 1 (each within the scatter of the next); then compound 3.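

Putting (cyclobutylmethyl)carbonyl in place of (2-nitrophenyl)sulfonyl on the amine nitrogen gives a 4.1-fold higher number from compound 2 to compound 3 (0.62 log units; beyond the scatter) in this assay, so this position can respond beyond the scatter, which the acetyl-to-sulfonyl step did not show. The acyl group alone also matters: cyclobutyl in place of hydrogen on the chain carbon bound to the carbonyl carbon gives a 2.4-fold higher number from compound 1 to compound 3 (0.38 log units; beyond the scatter). No supporting evidence is available to explain either step. On these data alone, it remains open whether a straight butyl chain, a phenyl ring or a terminal amine on the acyl group would weaken binding similarly. As far as these compounds go, it is also open whether plain phenylsulfonyl would match compound 2.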